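The source may report more compounds than this note shows. Statements on the series, on what has been measured and on what is new or still open speak of the compounds shown alone.

Compound 3 `Cc1cc(C(=O)O)nn1Cc1cc(Br)ccc1OCc1cccc(Br)c1` carries a 3-bromophenyl on the saturated chain carbon bound to the oxygen on the aromatic ring of the shared core. In an assay on CHO-K1 cells for displacement of a labelled ligand from prostaglandin E2 receptor EP1 subtype (Homo sapiens) (on this read-out higher numbers stand for weaker inhibition and lower numbers for stronger inhibition), compound 3 gives 17.8 nM, the highest number among the three measured compounds. Compound 1 `Cc1cc(C(=O)O)nn1Cc1cc(Br)ccc1OCc1ccc(Cl)cc1Cl` gives 0.132 nM and compound 2 `Cc1cc(C(=O)O)nn1Cc1cc(Br)ccc1OCc1ccc(F)cc1F` gives 0.525 nM in this assay; the steps of a 130-fold higher number from compound 1 to compound 3 (2.13 log units; beyond the scatter) and a 34-fold higher number from compound 2 to compound 3 (1.53 log units; beyond the scatter) are both large, and the step of a 4.0-fold higher number from compound 1 to compound 2 (0.60 log units; beyond the scatter) is modest. Compound 4 `Cc1cc(C(=O)O)nn1Cc1cc(Br)ccc1OCc1cccc(C(F)(F)F)c1` differs from compound 3 by trifluoromethyl in place of bromo on an aromatic carbon. Among the measured compounds shown here, no measured step exchanges bromo for trifluoromethyl, so the measured steps bear on it only loosely: they show that the substitution pattern on this phenyl ring moves this assay strongly, whereas compound 4 keeps a single group meta to a large group, as compound 3 does. The expected step of a 1.2-fold lower number from compound 3 to compound 4 (0.07 log units; within the scatter) is therefore small, possibly within the scatter, with no clear direction. Compound 4 is expected to give 15 nM in this assay, with a range from 4 nM to 60 nM.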

Compound 4, half-maximal inhibitory concentration: 309 nM
Beside the measured number, compound 4's estimate is 21-fold (1.31 log units) below it, outside the stated range (above it).
By their numbers in this assay, from the lowest: compound 1; then compound 2; then compound 3; then compound 4.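

Exchanging bromo for trifluoromethyl on an aromatic carbon, meta to a large group, is far from neutral in this assay, giving a 17-fold higher number from compound 3 to compound 4 (1.24 log units; beyond the scatter). The earlier steps shown here changed either the substitution pattern on this phenyl ring or both of its halogens at once, whereas here the pattern stays and a single group is exchanged, so the identity of that one group is enough to produce a large step. Nothing available bears on what lies behind this step.

The compounds shown leave open how other groups at this carbon, such as chloro, methyl, methoxy or a nitrile, would compare with bromo and trifluoromethyl. Going by these compounds, it also remains open whether trifluoromethyl would produce a similar step in place of a chloro on the 2,4-dichlorophenyl of compound 1.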